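The source may hold more compounds than are shown below. What is called first, only, known or untested is meant among the compounds shown, and "the series" means these compounds.

Measured so far in an ADME assay on the whole organism (Rattus norvegicus, strain Sprague-Dawley) for pharmacokinetics, read by LC-MS; a lower number here means that more of the compound stays in the plasma, a higher number that more of the compound sits outside the plasma:

- compound 1 `N#Cc1ccc(S(=O)(=O)[C@H]2CN(S(=O)(=O)c3ccc(Cl)cc3Cl)C[C@@H]2O)cc1`: 1.1 L/kg
- compound 2 `N#Cc1ccc(S(=O)(=O)[C@H]2CN(S(=O)(=O)c3ccc(Cl)cc3Cl)C[C@@]2(O)CO)cc1`: 2.3 L/kg

Compound 2 holds the higher number, 2.3 L/kg. Within the data shown here, its only neighbour, compound 1 at 1.1 L/kg, sits lower by more than the usual scatter. Compound 3 `N#Cc1ccc(S(=O)(=O)[C@H]2CN(S(=O)(=O)c3ccc(C#N)cc3Cl)C[C@@]2(O)CO)cc1` keeps everything in compound 2 except one group, with cyano in place of chloro on an aromatic carbon, so that 2,4-dichlorophenyl becomes 2-chloro-4-cyanophenyl: cyano in place of chloro on an aromatic carbon. Among the measured compounds shown here, no measured pair shows this swap, so any expectation here is only a rough one. The expected step of a 1.4-fold lower number from compound 2 to compound 3 (0.13 log units; within the scatter) stays within the scatter in this assay. Compound 3 is estimated at 1.7 L/kg, with an expected range of 0.9 L/kg to 3.2 L/kg.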

Compound 3, volume of distribution at steady state: 2.2 L/kg
The estimate for compound 3 lay 1.3-fold (0.11 log units) below the measured number; low and high end bracket the measured number.
By their numbers in this assay, from the lowest: compounds 1, 3 and 2 (each within the scatter of the next, the first and the last beyond it).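

Putting cyano in place of chloro on this aromatic carbon, para to a large group, gives a 1.0-fold lower number from compound 2 to compound 3 (0.02 log units; within the scatter) in this assay and so stays within the usual scatter. Among these compounds, this is the first measured view of this swap, and at this position the two groups cannot be told apart by this read-out. No supporting data bear on why they read alike. From the compounds shown here alone, whether an amine or a carboxylic acid on the same carbon would shift the number remains open. So does whether the swap would read the same on the core of compound 1.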